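This account rests on a few compounds, and the source may have more. Where it says the series, first, only, none or still open, it means among the compounds named here.

In a functional assay on K562 cells (Homo sapiens) for cytotoxicity, read by MTT assay (on this read-out lower numbers stand for stronger inhibition and higher numbers for weaker inhibition), compound 1 (`C#CCOc1cc(/C=C/C(=O)c2ccc(OC)c3c2OC(C)(C)C=C3)ccc1OC`) reaches only a limit, > 10000 nM. Compound 2 (`C=CCOc1cc(/C=C/C(=O)c2ccc(OC)c3c2OC(C)(C)C=C3)ccc1OC`) likewise gives only a limit, > 10000 nM. Compound 3 (`C=CC(=O)Oc1cc(/C=C/C(=O)c2ccc(OC)c3c2OC(C)(C)C=C3)ccc1OC`) gives a measured number, 300 nM. Compound 4 (`COc1ccc(/C=C/C(=O)c2ccc(OC)c3c2OC(C)(C)C=C3)cc1OC(=O)CCl`) differs from compound 1 as follows: (chloromethyl)carbonyl in place of propargyl on an oxygen on an aromatic ring. The measured steps that bear most closely on this change are an at least 33-fold lower number from compound 1 to compound 3 (1.52 log units; beyond the scatter) and an at least 33-fold lower number from compound 2 to compound 3 (1.52 log units; beyond the scatter). Both are large, and each places vinylcarbonyl on the same oxygen. Compound 4 also carries a carbonyl-bearing group there, so a similarly large drop is expected, an at least 16-fold lower number from compound 1 to compound 4 (1.22 log units; beyond the scatter). For compound 4, the estimated value is 600 nM, with an expected range from 120 nM to 3000 nM.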

Compound 4, half-maximal inhibitory concentration: 400 nM
The estimate for compound 4 lay 1.5-fold (0.18 log units) above the measured number, and the stated range covers the measured number.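

In this assay, (chloromethyl)carbonyl on this oxygen gives an at least 25-fold lower number from compound 1 to compound 4 (1.39 log units; beyond the scatter) and an at least 25-fold lower number from compound 2 to compound 4 (1.39 log units; beyond the scatter), so the large drop is no longer seen with vinylcarbonyl alone. Swapping the two carbonyl-bearing groups gives a 1.3-fold higher number from compound 3 to compound 4 (0.12 log units; within the scatter), so chloromethyl and vinyl on the carbonyl carbon cannot be told apart here. The two large steps are only bounds because compound 1 and compound 2 stand at a limit: the limit of > 10000 nM in this assay, at which 2 of the 4 values shown sit.

As far as these compounds go, it remains open whether a plain acetyl group, with neither vinyl nor chloromethyl on the carbonyl carbon, would give the same drop. A free hydroxyl on this oxygen also remains untested among the compounds shown.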